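Series at the assay limit: the naphthalen-2-yl swap

The compounds below may be only part of what the source reports. "The series", "measured", "known", "first", "only" and "open" are said of these compounds alone.

Measured in a functional assay on MCF7 cells (Homo sapiens) for antiproliferative activity, read by CellTiter-Glo, with a stated time of 5 days; a higher number here means a weaker inhibitor, a lower number a stronger inhibitor:
Compound 1 `CC/C(=C(/c1ccc(/C=C/C(=O)O)cc1)c1ccn2nccc2c1)c1ccccc1` gives > 500 nM (a limit)
Compound 2 `CC/C(=C(/c1ccc(/C=C/C(=O)O)cc1)c1ccc2cncn2c1)c1ccccc1` gives > 500 nM (a limit)
Compound 3 `CC/C(=C(/c1ccc(/C=C/C(=O)O)cc1)c1ccc2nnnn2c1)c1ccccc1` gives > 500 nM (a limit)

Compound 3 stands at a limit and has no number: > 500 nM. All measured compounds share this position: the limit of > 500 nM in this assay, at which 3 of the 3 values shown sit. Compound 4 `CC/C(=C(/c1ccc(/C=C/C(=O)O)cc1)c1ccc2ccccc2c1)c1ccccc1` arises from compound 3 through the change (a group of 10 heavy atoms (10 carbon; 2 six-membered aromatic rings of carbon only) in place of a group of 9 heavy atoms (5 carbon, 4 nitrogen; one five-membered aromatic ring with 4 hetero atoms, one six-membered aromatic ring with 1 hetero atom), on a double-bonded chain carbon bound to an aromatic carbon and a double-bonded chain carbon). The steps bearing on it are a step that the two limits leave unreadable from compound 1 to compound 2, a step that the two limits leave unreadable from compound 1 to compound 3 and a step that the two limits leave unreadable from compound 2 to compound 3. None supplies a size to carry over, so a modest move toward stronger inhibition in this assay is only a loose expectation, and another limit remains quite possible. The expected step is an at least 1.6-fold lower number from compound 3 to compound 4 (0.22 log units; that floor lies within the scatter). Compound 4 is expected at 300 nM, with an estimated range of 50 nM to 1500 nM.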

Compound 4, half-maximal inhibitory concentration: 180 nM
For compound 4 the middle estimate is 1.7-fold (0.22 log units) above the measured one; the range from low to high includes it.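

Naphthalen-2-yl gives the first readable number at this position in this assay and so separates itself from all three groups that carry ring nitrogen. Against their limits, the change reads as an at least 2.7-fold lower number from compound 3 to compound 4 (0.44 log units; beyond the scatter) and as an at least 2.7-fold lower number from compound 2 to compound 4 (0.44 log units; beyond the scatter) and as an at least 2.7-fold lower number from compound 1 to compound 4 (0.44 log units; beyond the scatter) (all bounds, not sizes). Only compound 4 leaves the limit: the limit of > 500 nM in this assay, at which 3 of the 4 values shown sit.

On these data alone, the steps among compounds 1, 2 and 3 cannot be read, so their order remains unknown. Also open, as far as these compounds go, is whether a methoxy group or an amine on the naphthalen-2-yl would keep a readable number.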